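The source may hold more compounds than are shown below. What is called first, only, known or untested is meant among the compounds shown, and "the series" means these compounds.

The measured compounds in an assay on microsomes from intestine for inhibition of acyl-CoA:cholesterol acyltransferase (Oryctolagus cuniculus); on this read-out lower numbers stand for stronger inhibition and higher numbers for weaker inhibition:

Compound 1, `CC(C)c1cccc(C(C)C)c1NC(=O)NCC1(c2cccs2)CCCC1`, gives 12 nM.
Compound 2, `CC(C)c1cccc(C(C)C)c1NC(=O)NCC1(c2ccsc2)CCCC1`, gives 18 nM.
Compound 3, `COc1ccccc1NC(=O)NCC1(c2ccccc2)CCCCC1`, gives 270 nM.

Compound 3 stands at the highest number of the three. Within the data shown here, compound 1 and compound 2 sit far lower, and they differ from compound 3 in several places at once, so their values show only that compound 3 is the weakest of the set, not what any single change is worth. Among the measured compounds shown here, the one step between compounds that differ in one place is a 1.5-fold higher number from compound 1 to compound 2 (0.18 log units; within the scatter), a swap on a saturated ring carbon that does not touch the aryl group on the urea nitrogen.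

Compound 4, `O=C(NCC1(c2ccccc2)CCCCC1)Nc1cc(Cl)ccc1Cl`, is not yet measured. It differs from compound 3 in this way: 2,5-dichlorophenyl in place of 2-methoxyphenyl on an amide-type nitrogen. For the measured compounds named here, no measured step bears on this change, because neither the aryl group on the amide-type nitrogen nor its substituents are varied among the measured compounds. The direction and size of the step in this assay are therefore open, and a step of either sign, or none beyond the scatter, would be consistent with what is known. Compound 4 is estimated at 150 nM, with a range from 40 nM to 600 nM, which means an expected step of a 1.8-fold lower number from compound 3 to compound 4 (0.26 log units; within the scatter).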

Compound 4, half-maximal inhibitory concentration: 2700 nM
The estimate for compound 4 lay 18-fold (1.26 log units) below the measured number; the whole stated range lies below it.
By their numbers in this assay, from the lowest: compounds 1 and 2 (each within the scatter of the next); then compound 3; then compound 4.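

In this assay, the aryl group on the amide-type nitrogen proves to be a place where the number moves well beyond the scatter: 2,5-dichlorophenyl in place of 2-methoxyphenyl gives a 10-fold higher number from compound 3 to compound 4 (1.00 log units; beyond the scatter). Among these compounds, this is the first reading of this position, and it shows that the swap weakens inhibition even though the entering and leaving groups have the same count of heavy atoms and the same aromatic ring of carbon only. Nothing measured here accounts for the size or direction of this step.

From the compounds shown here alone, it remains open whether the step comes from losing the methoxy group or from gaining either chlorine, which a 2-chlorophenyl, 3-chlorophenyl or unsubstituted phenyl group on that nitrogen would help to separate. Going by these compounds, it is also open whether the same swap would carry a step of similar size on the core of compound 1.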